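The source may report more compounds than this note shows. Statements on the series, on what has been measured and on what is new or still open speak of the compounds shown alone.

Compound 2 `CN1CCN(c2ccc(Nc3ncc4nc(SCc5ccccc5)n(C5CCOCC5)c4n3)cc2)CC1` is the reference point of this account. For the measured compounds named here, in a functional assay on HCC827 cells (Homo sapiens) for antiproliferative activity, read by MTT assay, with a stated time of 72 h (on this read-out lower numbers stand for stronger inhibition and higher numbers for weaker inhibition), compound 2 gives 107 nM, the lowest of the three numbers measured so far. Compound 3 `CC(C)n1c([S+]([O-])c2ccccc2)nc2cnc(Nc3ccc(N4CCN(C)CC4)cc3)nc21` gives 215 nM in this assay, a number within the scatter of compound 2. Compound 1 `CN1CCN(c2ccc(Nc3ncc4nc([S+]([O-])c5ccccc5)n(C5CCOCC5)c4n3)cc2)CC1` gives 411 nM in this assay, a number beyond the scatter above compound 2. Two single-point steps connect these compounds: a 3.8-fold lower number from compound 1 to compound 2 (0.58 log units; beyond the scatter), where a group holding a sulfur and an oxygen gave way to a group holding sulfur alone, and a 1.9-fold lower number from compound 1 to compound 3 (0.28 log units; within the scatter), where isopropyl took the place of oxan-4-yl on an aromatic nitrogen.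

Compound 4 `CN1CCN(c2ccc(Nc3ncc4nc([S+]([O-])Cc5cccnc5)n(C5CCOCC5)c4n3)cc2)CC1` differs from compound 2 in one place: a group of 9 heavy atoms (6 carbon, 1 nitrogen, 1 oxygen, 1 sulfur; one six-membered aromatic ring with 1 hetero atom) in place of a group of 8 heavy atoms (7 carbon, 1 sulfur; one six-membered aromatic ring of carbon only), on an aromatic carbon. Going by the values given here, the step from compound 1 to compound 2 bears on this change most directly, since compound 4 brings back a group with sulfur and oxygen; the exchange of a carbon-only ring for a ring with one hetero atom has no measured counterpart here. A modest rise in the number is therefore expected. Compound 4 is expected to give 280 nM in this assay, in a range from 100 nM to 800 nM. For compound 4 this means an expected step of a 2.6-fold higher number from compound 2 to compound 4 (0.42 log units; beyond the scatter).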

Compound 4, half-maximal inhibitory concentration: > 10000 nM
Compound 4 was reported as a limit; the forecaster's own chance of this, stated with the estimate: 3%; at least 35-fold (1.55 log units) between middle value and limit.
By their numbers in this assay, from the lowest: compounds 2, 3 and 1 (each within the scatter of the next, the first and the last beyond it). At a limit, above all of these: compound 4.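

In this assay compound 4 is reported only as a limit, not as a number: the limit of > 10000 nM in this assay, at which 1 of the 4 values shown sits. The group on the aromatic carbon between two ring nitrogen atoms can therefore move the result far more than compounds 1, 2 and 3 showed, with an at least 93-fold higher number from compound 2 to compound 4 (1.97 log units; beyond the scatter). The sulfur with its oxygen does not account for this on its own: compound 1 also carries that unit and gives 411 nM, yet the change on the sulfur alone, (pyridin-3-yl)methyl in place of phenyl, brings an at least 24-fold higher number from compound 1 to compound 4 (1.38 log units; beyond the scatter).

That last step still joins two changes, a methylene link and a ring nitrogen, and the compounds shown do not tell which of them matters, or whether only the two together do. On these data alone, a benzyl group on the same oxygen-bearing sulfur would separate them, while a pyridin-2-ylmethyl or pyridin-4-ylmethyl group would test where the ring nitrogen sits, and it remains open whether isopropyl in place of oxan-4-yl would change the outcome for the group of compound 4.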